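One More Methoxy Group on Compound 3

The source may hold more compounds than are shown below. What is called first, only, known or untested is meant among the compounds shown, and "the series" means these compounds.

Measured so far:
- compound 1, `COc1cc(/C=N/c2c(C#N)ncn2-c2ccc(F)cc2)ccc1O`: 13600 nM
- compound 2, `N#Cc1ncn(-c2ccc(F)cc2)c1/N=C/c1ccc(O)cc1`: 16300 nM
- compound 3, `COc1ccc(/C=N/c2c(C#N)ncn2Cc2ccc(F)cc2)cc1OC`: 9130 nM

In a functional assay on A549 cells (Homo sapiens) for antiproliferative activity, read by MTT assay, with a stated time of 48 h (on this read-out higher numbers stand for weaker inhibition and lower numbers for stronger inhibition), compound 2 gives 16300 nM and compound 1 gives 13600 nM. The two differ in one place: methoxy in place of hydrogen on an aromatic carbon. The step this made is a 1.2-fold lower number from compound 2 to compound 1 (0.08 log units; within the scatter), so the two values cannot be told apart.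

Compound 3 has a different core from compound 2, and the difference between the two cores is not broken down here. In this assay compound 3 gives 9130 nM, a number within the scatter of both compound 1 and compound 2.

Compound 4, `COc1ccc(/C=N/c2c(C#N)ncn2Cc2ccc(F)cc2)c(OC)c1OC`, has not yet been measured. Among the measured compounds shown here, it comes from compound 3 by the same kind of change as the one from compound 2 to compound 1: methoxy in place of hydrogen on an aromatic carbon. The surroundings differ, though: in compound 1 the new methoxy group sits ortho to a hydroxy group and meta to a large group, whereas in compound 4 it sits ortho to a large group, ortho to a methoxy group and meta to a methoxy group.

For the measured compounds named here, the one earlier example of this change, a 1.2-fold lower number from compound 2 to compound 1 (0.08 log units; within the scatter), stayed within the scatter. On that single precedent, the step in this assay from compound 3 to compound 4 is expected to be a 1.1-fold lower number from compound 3 to compound 4 (0.06 log units; within the scatter), again small. The estimate for compound 4 in this assay is therefore 8000 nM, with a plausible range from 3000 nM to 22000 nM.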

Compound 4, half-maximal inhibitory concentration: 24300 nM
Compound 4: middle estimate off by 3.0-fold (0.48 log units), on the low side; the whole stated range lies below it.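

In this assay the new methoxy group, here ortho to a large group, ortho to a methoxy group and meta to a methoxy group, gave a 2.7-fold higher number from compound 3 to compound 4 (0.43 log units; beyond the scatter) and so brought a modest loss of inhibition on the core of compound 3. Among the compounds shown here, these are only two examples, and they differ both in the core and in what surrounds the new group, so they cannot say which of the two matters, why the steps differ, or how the change would behave on a third core. What they do show is that in this series the effect of this change cannot simply be copied from one core to another, as the two steps are clearly not the same size: the same change on two cores in this assay, a 1.2-fold lower number (0.08 log units; within the scatter) from compound 2 to compound 1 and a 2.7-fold higher number (0.43 log units; beyond the scatter) from compound 3 to compound 4, 3.2-fold (0.50 log units) apart, beyond the scatter of two such steps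

Going by these compounds, what stays open is whether the loss belongs to the methoxy group itself or to any group placed there, and an amine or a longer chain such as ethoxy at that carbon would help to tell these apart. Also open, on these data alone, is how the two cores would compare if the methoxy group entered identical surroundings on each, which would separate the role of the core from that of the place.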